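This account rests on a few compounds, and the source may have more. Where it says the series, first, only, none or still open, it means among the compounds named here.

Of the compounds shown here, three that share a core have been measured in an assay on isolated protein for inhibition of Polyunsaturated fatty acid 5-lipoxygenase (Homo sapiens), read by HPLC, with stated times of 15 min and 10 min; on this read-out lower numbers stand for stronger inhibition and higher numbers for weaker inhibition. Compound 1 `Oc1cccc(Nc2nc(-c3ccc(Cl)cc3)cs2)c1` gives 1200 nM. Compound 2 `Oc1ccc(-c2csc(Nc3ccc(Cl)cc3)n2)cc1` gives 500 nM, the second highest of the three numbers; its value lies within the scatter of compound 3 `Nc1ccc(-c2csc(Nc3ccc(O)cc3)n2)cc1`, which gives 400 nM. The gap between compound 2 and compound 1 lies beyond the scatter. Compound 4 `O=S(=O)(c1ccc(-c2csc(Nc3ccc(Cl)cc3)n2)cc1)N1CCOCC1` has not yet been measured. It differs from compound 2 by (morpholin-4-yl)sulfonyl in place of hydroxy on an aromatic carbon. Within the data shown here, no measured pair shows this change, so its effect is not known from the data. The step is expected to be a 3.0-fold higher number from compound 2 to compound 4 (0.48 log units; beyond the scatter), a moderate move toward weaker inhibition, although a result close to compound 2 would not be surprising. Compound 4 is expected to give about 1500 nM, between 400 nM and 6000 nM.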

Compound 4, half-maximal inhibitory concentration: 2800 nM
For compound 4 the middle estimate is 1.9-fold (0.27 log units) below the measured one; measured number inside the range.
By their numbers in this assay, from the lowest: compounds 3 and 2 (each within the scatter of the next); then compound 1; then compound 4.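

Putting (morpholin-4-yl)sulfonyl in place of hydroxy on this aromatic carbon, para to a large group, gives a 5.6-fold higher number from compound 2 to compound 4 (0.75 log units; beyond the scatter) and so weakens inhibition. Among these compounds, this is the first step that changes one place only, and it shows that this position does not take the larger group without a loss. Nothing measured here accounts for that loss.

Going by these compounds, whether the loss follows from the sulfonyl link or from the morpholine ring remains open. So does how a plain sulfonamide or a methoxy group would compare with hydroxy at this position.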